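This account rests on a few compounds, and the source may have more. Where it says the series, first, only, none or still open, it means among the compounds named here.

Measured so far, in an in vitro assay on SH-EP1 cells for displacement of a labelled ligand from Neuronal acetylcholine receptor; alpha4/beta2 (Homo sapiens); a lower number here means a stronger inhibitor, a higher number a weaker inhibitor:
- compound 1 `Clc1cccc(Oc2cncc(C3=CC4CNCC(C3)C4)c2)c1`: compound 1 gives 1 nM
- compound 2 `COc1cccc(Oc2cncc(C3=CC4CNCC(C3)C4)c2)c1`: compound 2 gives 0.9 nM

Compound 2 stands at one end of the two numbers, with compound 1 right beside it: a 1.1-fold lower number from compound 1 to compound 2 (0.05 log units; within the scatter), so the two compounds are not distinguished in this assay.

Compound 3 `CC(C)Oc1cncc(C2=CC3CNCC(C2)C3)c1` differs from compound 2 by isopropyl in place of 3-methoxyphenyl on an oxygen on an aromatic ring. Within the data shown here, the single measured step, from compound 1 to compound 2, exchanges a substituent on the very phenyl ring that now leaves, so it does not bear directly on this change; it shows only that chloro and methoxy on that ring give the same result. Among the measured compounds shown here, no measured step removes the aromatic ring from the oxygen, so the change is untested here and larger than anything measured. The expectation is a somewhat weaker binding for compound 3, a 5.6-fold higher number from compound 2 to compound 3 (0.74 log units; beyond the scatter), with wide uncertainty. Compound 3 is estimated at 5 nM, in the range 1 nM to 30 nM.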

Compound 3, inhibition constant: 0.26 nM
Compound 3: middle estimate off by 19-fold (1.28 log units), on the high side; the whole stated range lies above it.
By their numbers in this assay, from the lowest: compound 3; then compounds 2 and 1 (each within the scatter of the next).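

In this assay, the aromatic ring on the ether oxygen proves unnecessary for strong binding: isopropyl in its place gives a 3.5-fold lower number from compound 2 to compound 3 (0.54 log units; beyond the scatter) and a 3.8-fold lower number from compound 1 to compound 3 (0.59 log units; beyond the scatter). Both steps point the same way, so the gain does not depend on which of the two aryl groups leaves, and this position takes a small group without a ring as well as it takes a substituted phenyl. Nothing on hand accounts for the gain.

The compounds shown leave open whether the gain comes from losing the aromatic ring or from the isopropyl group itself, and how far it extends to other groups on this oxygen. A methyl group, a longer chain such as n-butyl, or a chain ending in an amine would help to separate these readings.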